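Methoxy in Place of Methyl on the Aryl Ketone

A few compounds are considered here, and "the series" means these few. Any claim that something is new, unique, unknown or untested is made for them only; others in the source may bear on it.

Compound 1 `COc1cc(-c2nnc3n2NC(c2ccco2)C(C(=O)c2ccccc2C)S3)cc(OC)c1OC` stands second highest of the three numbers in a functional assay on HepG2 cells (Homo sapiens) for cytotoxicity, read by MTT assay, with a stated time of 48 h (on this read-out lower numbers stand for stronger inhibition and higher numbers for weaker inhibition), where compound 1 gives 63000 nM. Compound 2 `COc1cc(-c2nnc3n2NC(c2ccco2)C(C(=O)c2ccc(Cl)cc2)S3)cc(OC)c1OC` gives 78600 nM, and compound 3 `COc1cc(-c2nnc3n2NC(c2ccco2)C(C(=O)c2ccc(C)cc2)S3)cc(OC)c1OC` gives 17400 nM. The step of a 1.2-fold higher number from compound 1 to compound 2 (0.10 log units; within the scatter) lies within the scatter, whereas a 3.6-fold lower number from compound 1 to compound 3 (0.56 log units; beyond the scatter) and a 4.5-fold lower number from compound 2 to compound 3 (0.65 log units; beyond the scatter) are modest but beyond it. Compound 4 `COc1cccc(C(=O)C2Sc3nnc(-c4cc(OC)c(OC)c(OC)c4)n3NC2c2ccco2)c1` has not yet been measured; it differs from compound 1 as follows: 3-methoxyphenyl in place of 2-methylphenyl on a carbonyl carbon. Within the data shown here, no measured step exchanges 2-methylphenyl for 3-methoxyphenyl, so the steps that bear on this change are only those altering the same aryl group on the carbonyl carbon, a 1.2-fold higher number from compound 1 to compound 2 (0.10 log units; within the scatter) and a 3.6-fold lower number from compound 1 to compound 3 (0.56 log units; beyond the scatter), one within the scatter and one a modest fall. Compound 4 is therefore expected to give a number near that of compound 1, leaning somewhat lower, a 1.4-fold lower number from compound 1 to compound 4 (0.15 log units; within the scatter). The estimate for compound 4 in this assay is 45000 nM, with a range from 15000 nM to 130000 nM.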

Compound 4, half-maximal inhibitory concentration: > 100000 nM
Compound 4 gave a limit, no number (the forecaster's own chance of this, stated with the estimate: 10%); middle value at least 2.2-fold (0.34 log units) from the limit.
By their numbers in this assay, from the lowest: compound 3; then compounds 1 and 2 (each within the scatter of the next). At a limit, above all of these: compound 4.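

In this assay compound 4 gives a limit and not a number: the limit of > 100000 nM in this assay, at which 1 of the 4 values shown sits. The 3-methoxyphenyl group on the carbonyl carbon does not share the lower number of the 4-methylphenyl group, with an at least 5.7-fold higher number from compound 3 to compound 4 (0.75 log units; beyond the scatter), so among the four aryl groups shown, the 4-methylphenyl of compound 3 alone stands apart. Against the other two aryl groups the floors are an at least 1.5-fold higher number from compound 1 to compound 4 (0.20 log units; that floor lies within the scatter) and an at least 1.2-fold higher number from compound 2 to compound 4 (0.10 log units; that floor lies within the scatter), so neither step yet separates compound 4 from compound 1 or compound 2.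

Going by these compounds, how far compound 4 lies past its limit remains open, so its true distance from compound 1 and compound 2 is unknown. Also open, on these data alone, is how this position would answer to an amine or a carboxylic acid on the aryl ring, or to a longer chain in place of that ring.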